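Inverting the stereocentre of compound 1

This account rests on a few compounds, and the source may have more. Where it says the series, first, only, none or still open, it means among the compounds named here.

In a toxicity assay on HUVEC cells (Homo sapiens) for inhibition (on this read-out higher numbers stand for weaker inhibition of growth and lower numbers for stronger inhibition of growth), compound 1 (`COC(=O)c1ccsc1NC(=O)[C@@H]1CCCN1`) gives > 250 ug/mL, which is a limit of the assay. Compound 2 (`O=C(Oc1ccccc1)c1ccsc1NC(=O)[C@@H]1CCCN1`) gives > 250 ug/mL, also a limit. Compound 3 (`C=CCOC(=O)c1ccsc1NC(=O)[C@@H]1CCCN1`) gives 149 ug/mL. Two measured steps start at compound 1: a step that the two limits leave unreadable from compound 1 to compound 2, and an at least 1.6-fold lower number from compound 1 to compound 3 (0.22 log units; that floor lies within the scatter). Both change only the group on an oxygen next to a carbonyl group, so neither tests configuration. Compound 4 (`COC(=O)c1ccsc1NC(=O)[C@H]1CCCN1`) relates to compound 1 as follows: the two compounds have the same atoms and bonds and differ only in configuration as drawn: 1 of 1 stereo elements differ; a stereocentre at a saturated ring carbon is drawn S in compound 1 and R in compound 4. For the measured compounds named here, with no measured step at that stereocentre, no step beyond the scatter is expected in this assay, in either direction. The expected step is a number no higher from compound 1 to compound 4 (the limit leaves the size open). For compound 4 the estimate is 250 ug/mL, with an expected range from 120 ug/mL to 500 ug/mL.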

Compound 4, concentration for 50% growth inhibition: 95.8 ug/mL
Estimate against measurement, compound 4: 2.6-fold (0.42 log units) above; the measured number lies below the stated range.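

In this assay, drawing the saturated ring carbon as R rather than S gives an at least 2.6-fold lower number from compound 1 to compound 4 (0.41 log units; beyond the scatter), the only step shown that reads as beyond the scatter. Unlike the steps at the group on an oxygen next to a carbonyl group, this one can be laid to the stereocentre alone: the fact that compounds 1 and 4 differ only in the configuration as drawn. Its size is only a floor: the limit of > 250 ug/mL in this assay, at which 2 of the 4 values shown sit.

The compounds shown leave open whether the same inversion gives a like step with phenyl or allyl on that oxygen. They also leave open how a carboxylic acid or a longer chain there would read in this assay.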